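A few compounds are considered here, and "the series" means these few. Any claim that something is new, unique, unknown or untested is made for them only; others in the source may bear on it.

Among the compounds with values here, in a functional assay on the whole organism with Mus musculus as the target, in the rotarod test (on this read-out higher numbers stand for an effect only at larger amounts of compound and lower numbers for an effect already at smaller amounts), compound 1 `CN(C(=O)CNC(=O)CN)c1ccc([N+](=O)[O-])cc1C(=O)c1ccccc1Cl` gives 10 mg/kg, the only true number in this small set. Compound 2 `CN1CCN(CC(=O)NCC(=O)N(C)c2ccc(Cl)cc2C(=O)c2ccccc2Cl)CC1` reads > 100 mg/kg, which is a limit of the assay and not a number. Compound 3 `NC(C(=O)NCC(=O)Nc1ccc(Cl)cc1C(=O)c1ccccc1)c1ccccc1` reads > 100 mg/kg, and this too is a limit. Compound 2 therefore stands with compound 3 at the limit of > 100 mg/kg in this assay, at which 2 of the 3 values shown sit.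

Compound 4 `CCCC(=O)NCC(=O)N(C)c1ccc(Cl)cc1C(=O)c1ccccc1Cl` keeps the shared core of compound 2 and alters one group: ethyl in place of 4-methylpiperazin-1-yl on a saturated chain carbon bound to a carbonyl carbon. In plain words, ethyl takes the place of 4-methylpiperazin-1-yl on a saturated chain carbon bound to a carbonyl carbon. Within the data shown here, no measured pair in this set shows what such a swap does, so the expectation has to start from compound 2, whose limit is > 100 mg/kg. No step beyond the usual scatter is expected in this assay, in either direction. The estimated step is a number no higher from compound 2 to compound 4 (the limit leaves the size open). For compound 4 the expected value is 100 mg/kg, with an estimated range of 30 mg/kg to 300 mg/kg.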

Compound 4, dose for half-maximal effect: 55.2 mg/kg
The estimate for compound 4 lay 1.8-fold (0.26 log units) above the measured number; the range from low to high includes it.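

In this assay, compound 4 turns this place, a saturated chain carbon bound to a carbonyl carbon, into one that yields a true number, which the limit of compound 2 could not provide. Ethyl in place of 4-methylpiperazin-1-yl gives an at least 1.8-fold lower number from compound 2 to compound 4 (0.25 log units; that floor lies within the scatter), so the ring of compound 2 is not required for a measurable dose in this one pair. The real size of the step stays unknown, and the printed floor alone does not clear the scatter, because one end of the pair is a limit and not a number: the limit of > 100 mg/kg in this assay, at which 2 of the 4 values shown sit.

Going by these compounds, it remains open whether a longer chain such as hexyl, or a carboxylic acid, in this place would give a lower or a higher number. Compound 1 and compound 3 differ from compound 4 in more than one place, so they cannot settle this.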